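The compounds below may be only part of what the source reports. "The series", "measured", "known", "first", "only" and "open" are said of these compounds alone.

Three compounds share one core. Compound 2 `Nc1ccc(Nc2c(C(=O)NCc3ccc(F)cc3)nc(Br)c3cccnc23)cc1` and compound 3 `N[C@H]1CC[C@H](Nc2c(C(=O)NC3CCCCC3)nc(Br)c3cccnc23)CC1` have been tested in a functional assay on MCF7 cells (Homo sapiens) for cytotoxicity, read by MTT assay, with a stated time of 72 h (on this read-out higher numbers stand for weaker inhibition and lower numbers for stronger inhibition), while compound 1 `COc1cccc(CNC(=O)c2nc(Br)c3cccnc3c2N[C@H]2CC[C@H](N)CC2)c1` stands there as "not determined" (no result reported). In this assay compound 2 gives 4000 nM, and compound 3 gives 5200 nM. Of these two numbers, that of compound 2 is the lowest, yet its gap to compound 3 lies within the scatter, so no real difference between them can be claimed. Compound 4 `Nc1cccc(Nc2c(C(=O)NCc3ccc(F)cc3)nc(Br)c3cccnc23)c1` is not yet measured; it differs from compound 2 by 3-aminophenyl in place of 4-aminophenyl on a nitrogen on an aromatic ring. For the measured compounds named here, no measured pair shows a change of this kind, so its size is unknown; the expected step of a 1.3-fold higher number from compound 2 to compound 4 (0.10 log units; within the scatter) is none beyond the scatter, in either direction. Compound 4 is therefore estimated at 5000 nM, within a range from 2000 nM to 12000 nM.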

Compound 4, half-maximal inhibitory concentration: 8000 nM
The estimate for compound 4 lay 1.6-fold (0.20 log units) below the measured number; the range from low to high includes it.
By their numbers in this assay, from the lowest: compounds 2, 3 and 4 (each within the scatter of the next).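

On the nitrogen on an aromatic ring, 3-aminophenyl in place of 4-aminophenyl gives a 2.0-fold higher number from compound 2 to compound 4 (0.30 log units; within the scatter) in this assay. For the compounds shown here, this is the first comparison here that changes only one place, and with the same atoms joined differently, no real difference can be claimed at this position. Nothing available explains the result. From the compounds shown here alone, it remains open whether a carboxylic acid or a hydroxyl group in place of the amine on this phenyl ring would shift the number beyond the scatter.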